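Swapping the heteroaryl group on the ketone side chain

The source may hold more compounds than are shown below. What is called first, only, known or untested is meant among the compounds shown, and "the series" means these compounds.

Measured so far in a functional assay on Jurkat cells (Homo sapiens) for inhibition; a higher number here means a weaker inhibitor, a lower number a stronger inhibitor:
- compound 1 `CC(C)[C@H](NC(=O)COc1cccc2ccccc12)C(=O)N[C@@H](CC(=O)O)C(=O)CSc1nc[nH]n1`: > 200000 nM
- compound 2 `CC(C)[C@H](NC(=O)COc1cccc2ccccc12)C(=O)N[C@@H](CC(=O)O)C(=O)COc1cc(C(F)(F)F)ncn1`: > 200000 nM

Compound 2 stands at a limit of this assay, not at a number. Compound 1 likewise sits at a limit. For the measured compounds named here, the one measured step, a step that the two limits leave unreadable from compound 1 to compound 2, therefore cannot be read, and the only evidence is the limit of > 200000 nM in this assay, at which 2 of the 2 values shown sit.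

Compound 3 `CC(C)[C@H](NC(=O)COc1cccc2ccccc12)C(=O)N[C@@H](CC(=O)O)C(=O)CSc1nccc(C(F)(F)F)n1` differs from compound 2 by (4-(trifluoromethyl)pyrimidin-2-yl)sulfanyl in place of (6-(trifluoromethyl)pyrimidin-4-yl)oxy on a saturated chain carbon bound to a carbonyl carbon. The step from compound 2 to compound 3 is thus a further exchange of the heteroaryl group at the same place; the measured step that bears on it is unreadable, so its size gives no guidance in either direction. With both measured compounds at the limit, compound 3 is expected to show no readable step, a step that the limit leaves unreadable from compound 2 to compound 3, and to remain at the same limit. The estimate for compound 3 in this assay is 300000 nM, within 100000 nM to 1000000 nM.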

Compound 3, half-maximal inhibitory concentration: > 200000 nM
Compound 3 was reported as a limit (the forecaster's own chance of this, stated with the estimate: 85%); the middle value is on the limit's open side.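

In this assay compound 3 gives > 200000 nM, which is a limit and not a number. The steps linking compound 1, compound 2 and compound 3 therefore cannot be read: the limit of > 200000 nM in this assay, at which 3 of the 3 values shown sit.

The compounds shown leave open how far apart these three compounds lie in this assay.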